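Cyclopropyl to tert-butyl on the saturated chain carbon

The source may report more compounds than this note shows. Statements on the series, on what has been measured and on what is new or still open speak of the compounds shown alone.

Compound 1 `CCc1nc2ccc(-n3ccc(OCc4ccc(F)cc4)cc3=O)cc2n1C` gives 38 nM in an assay on CHO cells for displacement of a labelled ligand from melanin-concentrating hormone receptor 1 (Rattus norvegicus), read by scintillation counting, with a stated time of 1 h; a lower number here means a stronger inhibitor, a higher number a weaker inhibitor.
Compound 2 `Cn1c(CC2CC2)nc2ccc(-n3ccc(OCc4ccc(F)cc4)cc3=O)cc21` gives 140 nM in this assay.

Compound 2 stands at the higher of the two numbers. Among the measured compounds shown here, the one measured step that bears on the next change is a 3.7-fold higher number from compound 1 to compound 2 (0.57 log units; beyond the scatter), a move beyond the scatter toward weaker inhibition as the group on that carbon grew. For the measured compounds named here, compound 3 `Cn1c(CC(C)(C)C)nc2ccc(-n3ccc(OCc4ccc(F)cc4)cc3=O)cc21` carries tert-butyl in place of cyclopropyl on a saturated chain carbon bound to an aromatic carbon, a further enlargement at the same place, for which no measured step exists. Compound 3 is expected to give about 300 nM, within 90 nM to 1000 nM. That expectation amounts to a 2.1-fold higher number from compound 2 to compound 3 (0.33 log units; beyond the scatter), a modest further weakening.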

Compound 3, half-maximal inhibitory concentration: > 1000 nM
Compound 3 ended at the assay's limit; the forecaster's own chance of this, stated with the estimate: 5%; middle value at least 3.3-fold (0.52 log units) away from the limit.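

In this assay compound 3 gives > 1000 nM, which is a limit of the assay and not a number. Tert-butyl in place of cyclopropyl brings an at least 7.1-fold higher number from compound 2 to compound 3 (0.85 log units; beyond the scatter), and tert-butyl in place of methyl brings an at least 26-fold higher number from compound 1 to compound 3 (1.42 log units; beyond the scatter). The number therefore rises from methyl through cyclopropyl to tert-butyl, with none of the three compounds going against this order, though the full size of the last rise cannot be read.

Three compounds cannot separate the loss of the ring from the added carbon in this change. From the compounds shown here alone, how a straight propyl chain or an amine on this carbon would read in this assay remains open.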